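The source may hold more compounds than are shown below. What is called first, only, known or untested is meant among the compounds shown, and "the series" means these compounds.

Series notes.

Compound 1 `COc1ccc(C2=NN(C3=NC(=O)/C(=C4\C(=O)Nc5ccccc54)S3)C(c3ccc(OC)cc3)C2)cc1` is the parent of the set. In a functional assay on cells (Cancer cell lines, Homo sapiens) for cytotoxicity, read by sulforhodamine B assay, with a stated time of 48 h (a higher number here means a weaker inhibitor of growth, a lower number a stronger inhibitor of growth), compound 1 gives 89200 nM. Compound 2 `COc1ccc(C2=NN(C3=NC(=O)/C(=C4\C(=O)Nc5ccc(Br)cc54)S3)C(c3ccc(OC)cc3)C2)cc1` carries the change bromo in place of hydrogen on an aromatic carbon on the core of compound 1, and in this assay compound 2 gives 405 nM. This change makes the step of a 220-fold lower number from compound 1 to compound 2 (2.34 log units; beyond the scatter), the one large movement among the measured compounds.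

Compound 3 `COc1ccc(C2=NN(C3=NC(=O)/C(=C4\C(=O)Nc5ccccc54)S3)C(c3ccc(Cl)cc3)C2)cc1` differs from compound 1 by chloro in place of methoxy on an aromatic carbon, and in this assay compound 3 gives 100000 nM. The step of a 1.1-fold higher number from compound 1 to compound 3 (0.05 log units; within the scatter) shows that the two cores, that of compound 1 and that of compound 3, are read alike in this assay.

Compound 4 `COc1ccc(C2=NN(C3=NC(=O)/C(=C4\C(=O)Nc5ccc(Br)cc54)S3)C(c3ccc(Cl)cc3)C2)cc1` is not yet measured. Among the measured compounds shown here, it differs from compound 3 by bromo in place of hydrogen on an aromatic carbon, which is the same change as the one from compound 1 to compound 2, made on the core of compound 3 instead. The two values of compound 2 and compound 4 are the matched pair across the cores.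

For the measured compounds named here, since the two cores stand together in this assay and the one earlier instance of this change gave a 220-fold lower number from compound 1 to compound 2 (2.34 log units; beyond the scatter), a step of about the same size is expected from compound 3 to compound 4, namely a 220-fold lower number from compound 3 to compound 4 (2.35 log units; beyond the scatter). The expectation rests on a single prior instance, so the range is kept wide. The estimate for compound 4 in this assay is 450 nM, with a range from 150 nM to 2000 nM.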

Compound 4, concentration for total growth inhibition: 1480 nM
Compound 4: the middle estimate sits 3.3-fold (0.52 log units) below what was measured; low and high end bracket the measured number.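

In this assay the bromo change carries over to the second core in the same direction and remains large, with a 68-fold lower number from compound 3 to compound 4 (1.83 log units; beyond the scatter), but its size does not carry over unchanged: the same change on two cores in this assay, a 220-fold lower number (2.34 log units; beyond the scatter) from compound 1 to compound 2 and a 68-fold lower number (1.83 log units; beyond the scatter) from compound 3 to compound 4, 3.3-fold (0.51 log units) apart, beyond the scatter of two such steps.

Read the other way round, chloro in place of methoxy makes no difference beyond the scatter on the core of compound 1, yet on the core of compound 2 it gives a 3.7-fold higher number from compound 2 to compound 4 (0.56 log units; beyond the scatter), so the two changes do not add up independently here: the same change on two cores in this assay, a 1.1-fold higher number (0.05 log units; within the scatter) from compound 1 to compound 3 and a 3.7-fold higher number (0.56 log units; beyond the scatter) from compound 2 to compound 4, 3.3-fold (0.51 log units) apart, beyond the scatter of two such steps.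

The square of compounds 1 to 4 shows that a step measured on one core gives the direction on the other but not a reliable size; as a single pair of cores, it does not show why the sizes differ or how the bromo change would behave on any further core.

Still open, as far as these compounds go, is whether bromo is specifically required at this aromatic carbon, or whether fluoro, chloro, methyl or nitrile there would give a step of similar size. Also open, from the compounds shown here alone, is how the series responds when the chloro or methoxy group gives way to an amine or a carboxylic acid, or when a methyl group or a longer chain replaces the amide hydrogen.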